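Fluoro to Imidazolyl: What Compound 4 Might Show

A few compounds are considered here, and "the series" means these few. Any claim that something is new, unique, unknown or untested is made for them only; others in the source may bear on it.

Compound 1 `COc1ccc(C(=O)/C=C/c2ccc(F)cc2)c2c1C=CC(C)(C)O2`: in a functional assay on HT-29 cells (Homo sapiens) for antiproliferative activity, read by MTT assay, with a stated time of 24 h (a higher number here means a weaker inhibitor, a lower number a stronger inhibitor), compound 1 gives > 10000 nM, which is a limit of the assay.
Compound 2 `COc1ccc(C(=O)/C=C/c2ccc3ccccc3c2)c2c1C=CC(C)(C)O2`: in this assay compound 2 gives 4480 nM.
Compound 3 `COc1ccc(C(=O)/C=C/c2ccc(N(c3ccccc3)c3ccccc3)cc2)c2c1C=CC(C)(C)O2`: in this assay compound 3 gives > 10000 nM, again a limit.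

Among the measured compounds shown here, compound 1 thus stands only at the limit of > 10000 nM in this assay, at which 2 of the 3 values shown sit, with no number of its own; compound 2 supplies the one numerical value among the three. Compound 4 `COc1ccc(C(=O)/C=C/c2ccc(-n3ccnc3)cc2)c2c1C=CC(C)(C)O2` differs from compound 1 by 1H-imidazol-1-yl in place of fluoro on an aromatic carbon. For the measured compounds named here, no measured pair differing in one place is available, so compound 2 and compound 3 only show that other groups in that place can give a number or stay at the limit. The step from compound 1 to compound 4 is expected to be an at least 1.1-fold lower number from compound 1 to compound 4 (0.04 log units; that floor lies within the scatter), no clear move beyond the scatter. Compound 4 is estimated at 9000 nM, between 2500 nM and 30000 nM.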

Compound 4, half-maximal inhibitory concentration: > 6600 nM
Compound 4: a limit, no number; the forecaster's own chance of this, stated with the estimate: 55%; the middle value lies beyond the limit too.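

In this assay compound 4 gives > 6600 nM, a limit and not a number. Among the compounds shown here, compound 1 also stands at a limit, so no step between compound 1 and compound 4 can be read. As far as these compounds go, whether 1H-imidazol-1-yl in place of fluoro changes activity stays open.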